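Shrinking the Ring Amine of Compound 2

This account rests on a few compounds, and the source may have more. Where it says the series, first, only, none or still open, it means among the compounds named here.

Three compounds have been measured in an assay on isolated protein for displacement of a labelled ligand from melanin-concentrating hormone receptor 1 (Homo sapiens); a lower number here means a stronger inhibitor, a higher number a weaker inhibitor:

compound 1 `CCCc1cc(N)c2cc(NC(=O)/C=C/c3ccc(Cl)cc3)ccc2n1` gives 6 nM
compound 2 `CCCc1cc(N2CCCCC2)c2cc(NC(=O)/C=C/c3ccc(C(F)(F)F)cc3)ccc2n1` gives > 4000 nM
compound 3 `CCCc1cc(N)c2cc(NC(=O)c3ccc(-c4ccc(Cl)cc4)cc3)ccc2n1` gives 0.7 nM

Compound 2 stands apart from the other two: its value is a limit of this assay, not a number, and it sits at the limit of > 4000 nM in this assay, at which 1 of the 3 values shown sits. Compound 1 and compound 3, which carry a free amine where compound 2 carries a piperidin-1-yl, both give numbers far below that limit.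

Compound 4 `CCCc1cc(N2CCCC2)c2cc(NC(=O)/C=C/c3ccc(C(F)(F)F)cc3)ccc2n1` has not yet been measured. It differs from compound 2 in one place, (pyrrolidin-1-yl in place of piperidin-1-yl on an aromatic carbon), the ring amine losing one carbon of its saturated ring while everything else in the molecule stays the same.

With only a limit for compound 2, the step to compound 4 in this assay is expected to be small, and no change beyond the usual scatter is expected. Compound 4 is estimated at 6000 nM, in the range 1500 nM to 30000 nM, so that the step that the limit leaves unreadable from compound 2 to compound 4 is expected to leave it near the limit.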

Compound 4, half-maximal inhibitory concentration: 17 nM
Compound 4: the middle estimate sits 350-fold (2.55 log units) above what was measured; measured number below the stated range.
By their numbers in this assay, from the lowest: compound 3; then compound 1; then compound 4. At a limit, above all of these: compound 2.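

In this assay, the saturated ring on the aromatic carbon opposite the ring nitrogen proves highly sensitive to a single ring carbon: the change from piperidin-1-yl to pyrrolidin-1-yl gives an at least 230-fold lower number from compound 2 to compound 4 (2.37 log units; beyond the scatter). Compound 1 and compound 3 carry a free amine at this place and differ from compound 2 elsewhere as well, so they could not show that a ring amine is tolerated here, whereas compound 4 does so with 17 nM. The size of the step has only a lower bound, as the value of compound 2 is a limit and not a number: the limit of > 4000 nM in this assay, at which 1 of the 4 values shown sits.

The compounds shown leave open whether ring size alone governs this position, which an azetidine or a morpholine in the same place would help to settle. As far as these compounds go, it also remains open whether pyrrolidin-1-yl would be tolerated alongside the biaryl amide of compound 3.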